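The source may report more compounds than this note shows. Statements on the series, on what has been measured and on what is new or still open speak of the compounds shown alone.

Measured compounds in a functional assay on MCF7 cells (Homo sapiens) for cytotoxicity, read by MTT assay, with a stated time of 24 h; on this read-out lower numbers stand for stronger inhibition and higher numbers for weaker inhibition:
compound 1 `Cn1c(-c2ccc(NC(=O)CCl)cc2)nc(-c2ccccc2)c1-c1ccccc1` — compound 1 gives 42.6 ug/mL
compound 2 `Cn1c(-c2ccc(NC(=O)CSc3nc4cc(Cl)ccc4o3)cc2)nc(-c2ccccc2)c1-c1ccccc1` — compound 2 gives 21.7 ug/mL
compound 3 `Cc1ccc2oc(SCC(=O)Nc3ccc(-c4nc(-c5ccccc5)c(-c5ccccc5)n4C)cc3)nc2c1` — compound 3 gives 22.4 ug/mL

Compound 2 holds the lowest of the three numbers, yet it sits within the scatter of both neighbours: a 2.0-fold lower number from compound 1 to compound 2 (0.29 log units; within the scatter) and a 1.0-fold higher number from compound 2 to compound 3 (0.01 log units; within the scatter). The change from compound 1 to compound 3 is likewise small, a 1.9-fold lower number from compound 1 to compound 3 (0.28 log units; within the scatter). Across the three, nothing beyond the scatter separates any pair.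

Compound 4 `Cn1c(-c2ccc(NC(=O)CSc3nc4ccccc4s3)cc2)nc(-c2ccccc2)c1-c1ccccc1` is not yet measured. It differs from compound 2 as follows: 1,3-benzothiazol-2-yl in place of 5-chloro-1,3-benzoxazol-2-yl on a sulfur. For the measured compounds named here, the one measured step that touches the same part of the molecule is the change of the substituent on the aromatic carbon from compound 2 to compound 3, which was a 1.0-fold higher number from compound 2 to compound 3 (0.01 log units; within the scatter). Going by the values given here, no measured step covers the exchange of the five-membered ring's oxygen for sulfur, so that part rests on no data. Given that both substituent changes at this end of the chain stayed within the scatter, the step from compound 2 to compound 4 in this assay is expected to be a 1.0-fold higher number from compound 2 to compound 4 (0.01 log units; within the scatter), with no direction favoured. Compound 4 is therefore estimated at 22 ug/mL, with a range from 11 ug/mL to 45 ug/mL.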

Compound 4, half-maximal inhibitory concentration: 15.8 ug/mL
Estimate against measurement, compound 4: 1.4-fold (0.14 log units) above; low and high end bracket the measured number.
By their numbers in this assay, from the lowest: compounds 4, 2, 3 and 1 (each within the scatter of the next, the first and the last beyond it).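

In this assay, the whole heteroaryl group on the sulfur can be exchanged without leaving the scatter: 1,3-benzothiazol-2-yl in place of 5-chloro-1,3-benzoxazol-2-yl gives (a 1.4-fold lower number from compound 2 to compound 4 (0.14 log units; within the scatter)), and in place of 5-methyl-1,3-benzoxazol-2-yl it gives (a 1.4-fold lower number from compound 3 to compound 4 (0.15 log units; within the scatter)). The sulfanyl group on the saturated chain carbon now yields the first separation from the chloro compound, though a modest one (a 2.7-fold lower number from compound 1 to compound 4 (0.43 log units; beyond the scatter)). Compound 2 and compound 3 go against any general reading. Their steps from compound 1 stay within the scatter. No independent measurement bears on this result.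

From the compounds shown here alone, it remains open how much of the exchange belongs to the ring sulfur and how much to the loss of the chlorine. Also open, going by these compounds, is how an amine such as piperidine on the saturated chain carbon, in place of the sulfanyl group, would read in this assay.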